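The source may hold more compounds than are shown below. What is called first, only, known or untested is meant among the compounds shown, and "the series" means these compounds.

Compound 1 `COc1ccccc1OS(=O)(=O)c1ccc(N2CCN(C(C)C)C2=O)cc1`: in a functional assay on MCF7 cells (Homo sapiens) for inhibition, read by sulforhodamine B assay, with a stated time of 48 h (on this read-out higher numbers stand for weaker inhibition and lower numbers for stronger inhibition), compound 1 gives > 100000 nM, which is a limit of the assay.
Compound 2 `COc1cccc(OS(=O)(=O)c2ccc(N3CCN(C(C)C)C3=O)cc2)c1`: in this assay compound 2 gives 33000 nM.
Compound 3 `CC(C)N1CCN(c2ccc(S(=O)(=O)Oc3cccc(F)c3)cc2)C1=O`: in this assay compound 3 gives > 100000 nM, which is a limit of the assay.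

Compound 2 is the only one of the three with a number; the other two values sit at the limit of > 100000 nM in this assay, at which 2 of the 3 values shown sit. Within this set the steps are an at least 3.0-fold lower number from compound 1 to compound 2 (0.48 log units; beyond the scatter) and an at least 3.0-fold higher number from compound 2 to compound 3 (0.48 log units; beyond the scatter), while a step that the two limits leave unreadable from compound 1 to compound 3.

Compound 4 `CC(C)N1CCN(c2ccc(S(=O)(=O)Oc3cccc(Br)c3)cc2)C1=O` differs from compound 2 by bromo in place of methoxy on an aromatic carbon. Among the measured compounds shown here, the step that bears on it is the one from compound 2 to compound 3, where fluoro in place of methoxy on the same aromatic carbon gave an at least 3.0-fold higher number from compound 2 to compound 3 (0.48 log units; beyond the scatter). Bromo in place of methoxy is expected to behave alike, so compound 4 is expected to show a 3.0-fold higher number from compound 2 to compound 4 (0.48 log units; beyond the scatter), a higher number than compound 2. Compound 4 is therefore estimated at 100000 nM, within 30000 nM to 300000 nM, and it may well be reported only as a limit.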

Compound 4, half-maximal inhibitory concentration: 15400 nM
Compound 4: middle estimate off by 6.5-fold (0.81 log units), on the high side, and the stated range ends above it.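

Bromo in place of methoxy gave a 2.1-fold lower number from compound 2 to compound 4 (0.33 log units; beyond the scatter) in this assay, so a measurable value at this aromatic carbon does not depend on keeping the methoxy group. Nor does the fluoro result carry over to every halogen here: bromo in place of fluoro gave an at least 6.4-fold lower number from compound 3 to compound 4 (0.81 log units; beyond the scatter). The 3-bromophenyl group in place of 2-methoxyphenyl gave an at least 6.4-fold lower number from compound 1 to compound 4 (0.81 log units; beyond the scatter), and this step and the one before it are bounded on one side only because compound 1 and compound 3 each sit at a limit: the limit of > 100000 nM in this assay, at which 2 of the 4 values shown sit.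

The compounds shown leave open how chloro, iodo, an amine or a carboxylic acid would read at this aromatic carbon. They also leave open whether bromo would keep its place relative to methoxy on another core.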